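The compounds below may be only part of what the source reports. "The series", "measured", "known", "first", "only" and "open" are said of these compounds alone.

Two compounds have been measured in an assay on cells for inhibition of HSP60/HSP10 (Homo sapiens), with a stated time of 60 min; on this read-out higher numbers stand for weaker inhibition and lower numbers for stronger inhibition:

compound 1, `O=S(=O)(Nc1ccc(-c2nc3ccccc3o2)cc1)c1cccc(F)c1`, gives 71000 nM
compound 2, `CCc1ccc(S(=O)(=O)Nc2ccc3oc(-c4ccccc4)nc3c2)cc1`, gives only a limit, > 100000 nM

Compound 1 thus stands on the only actual number shown; the other reading is a limit. Compound 2 sits at the limit of > 100000 nM in this assay, at which 1 of the 2 values shown sits, so it contributes a boundary and not a point to compare against. Going by the values given here, no pair of measured compounds differs in a single place, and so no measured step is available to lean on.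

Compound 3, `Cc1cccc(S(=O)(=O)Nc2ccc(-c3nc4ccccc4o3)cc2)c1`, is the compound not yet measured. It differs from compound 1 by methyl in place of fluoro on an aromatic carbon, the change reading as 3-fluorophenyl to 3-methylphenyl when cut one bond further out. Among the compounds with values here, with no measured step to guide the size, the expectation rests on the two structures alone: a step from compound 1 to compound 3 of about a 1.0-fold lower number from compound 1 to compound 3 (0.01 log units; within the scatter) is expected, that is, nothing beyond the usual scatter in either direction. Compound 3 is therefore estimated at 70000 nM, within a range from 30000 nM to 150000 nM.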

Compound 3, half-maximal inhibitory concentration: > 100000 nM
Compound 3 ended at the assay's limit (the forecaster's own chance of this, stated with the estimate: 35%); middle value at least 1.4-fold (0.15 log units) from the limit.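

In this assay, compound 3 gives only a limit, > 100000 nM, and not a number. Methyl in place of fluoro, on an aromatic carbon meta to a large group, provides the first measured step at this position, an at least 1.4-fold higher number from compound 1 to compound 3 (0.14 log units; that floor lies within the scatter), and since that step has only a floor, its true size could be small or large. Going by these compounds alone, the change from 3-fluorophenyl to 3-methylphenyl therefore does not bring a stronger reading, and the only actual number stays with the 3-fluorophenyl compound, while the methyl compound joins the boundary: the limit of > 100000 nM in this assay, at which 2 of the 3 values shown sit.

The compounds shown leave open how far past the limit compound 3 lies, and so whether fluoro and methyl truly differ at this position or merely fall on either side of the limit of the read-out. They also leave open whether anything at this position can give a clearly stronger reading than compound 1, such as a chloro, a methoxy, an amine or a carboxylic acid on the same aromatic carbon.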